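The compounds below may be only part of what the source reports. "The series", "measured", "known", "first", "only" and "open" are said of these compounds alone.

Going by the values given here, in a functional assay on HeLa cells (Homo sapiens) for inhibition, with a stated time of 72 h (on this read-out higher numbers stand for weaker inhibition and lower numbers for stronger inhibition), compound 1 (`NC1CCC(Nc2nc(NCc3ccc(-c4ccccc4)cc3)c3ncn(C4CCCC4)c3n2)CC1`) gives 240 nM as the highest of the three numbers measured so far. Compound 2 (`NC1CCC(Nc2nc(NCc3ccc(-c4cccs4)nc3)c3ncn(C4CCCC4)c3n2)CC1`) stands at 40 nM and compound 3 (`NC1CCC(Nc2nc(NCc3ccc(-c4ccsc4)nc3)c3ncn(C4CCCC4)c3n2)CC1`) at 75 nM on the same scale. Putting 6-(thiophen-2-yl)pyridin-3-yl in place of 4-phenylphenyl gives a modest step (a 6.0-fold lower number from compound 1 to compound 2 (0.78 log units; beyond the scatter)) and 6-(thiophen-3-yl)pyridin-3-yl gives another (a 3.2-fold lower number from compound 1 to compound 3 (0.51 log units; beyond the scatter)), while the two thiophene forms stay within the scatter of each other (a 1.9-fold higher number from compound 2 to compound 3 (0.27 log units; within the scatter)).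

Compound 4 (`NC1CCC(Nc2nc(NCc3ccc(-c4ccccc4O)cc3)c3ncn(C4CCCC4)c3n2)CC1`) differs from compound 1 in one place (hydroxy in place of hydrogen on an aromatic carbon) with hydroxy in place of hydrogen on an aromatic carbon, ortho to a large group. Among the compounds with values here, no measured step makes this change. The steps from compound 1 exchange the whole group, so they bear on it only loosely, showing that the number can move modestly when this part of the molecule is altered. In this assay a step no larger than those is therefore expected, with a slight lean towards a lower number, and it may well not leave the scatter. The estimated step (a 1.4-fold lower number from compound 1 to compound 4 (0.15 log units; within the scatter)) is accordingly small. For compound 4 the expected value is 170 nM (estimated range 60 nM to 480 nM).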

Compound 4, half-maximal inhibitory concentration: 4180 nM
For compound 4 the middle estimate is 25-fold (1.39 log units) below the measured one; the measured number lies above the stated range.
By their numbers in this assay, from the lowest: compounds 2 and 3 (each within the scatter of the next); then compound 1; then compound 4.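

In this assay, hydroxy in place of hydrogen on an aromatic carbon, ortho to a large group, gives the largest step seen so far in this part of the molecule, a 17-fold higher number from compound 1 to compound 4 (1.24 log units; beyond the scatter). This step runs in the opposite direction to the steps that lead to compounds 2 and 3. Those earlier steps exchanged the whole group and only ever lowered the number, whereas compound 4 shows that the change from phenyl to 2-hydroxyphenyl, which adds only 1 heavy atom, can raise it steeply, so this place on the ring is far from indifferent to substitution. Nothing available explains the rise in the number.

The compounds shown leave open whether the rise belongs to hydroxy in particular or to any group on this carbon, a question that a methoxy group or a fluorine atom in the same place would help to settle. They also leave open whether an amine on this ring would behave in the same way, and whether the thiophene-bearing compounds 2 and 3 would respond to hydroxy as compound 1 does.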